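Selenium to Methylsulfanyl on a Fused Core

The source may report more compounds than this note shows. Statements on the series, on what has been measured and on what is new or still open speak of the compounds shown alone.

compound 1 `COc1ccc(CNc2nc(SC)nc3ccccc23)cc1` — 93700 nM
compound 2 `[SeH]c1nc(NCc2ccccc2)c2ccccc2n1` — > 100000 nM

In a functional assay on CCRF-CEM cells (Homo sapiens) for cytotoxicity, read by MTT assay, with a stated time of 72 h (on this read-out lower numbers stand for stronger inhibition of growth and higher numbers for weaker inhibition of growth), compound 1 gives 93700 nM. For compound 2 the read-out is only a limit, > 100000 nM, so no number is known for it. This is the limit of > 100000 nM in this assay, at which 1 of the 2 values shown sits. Compound 3, `CSc1nc(NCc2ccccc2)c2ccccc2n1`, has not been measured and differs from compound 2 by a group of 2 heavy atoms (1 carbon, 1 sulfur; no ring) in place of one selenium atom, on an aromatic carbon. No step between two measured compounds is available, so nothing shown tells how large such a change can be. Compound 1 carries the same methylsulfanyl group as compound 3 and shows a weak value in this assay. Compound 3 is expected to show a step of an at least 1.1-fold lower number from compound 2 to compound 3 (0.04 log units; that floor lies within the scatter) that may not go beyond the scatter. Compound 3 is estimated at 90000 nM, between 40000 nM and 200000 nM.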

Compound 3, concentration for 50% growth inhibition: 87900 nM
Compound 3: middle estimate off by 1.0-fold (0.01 log units), on the high side, within the range that was stated.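

In this assay, going by these compounds, one selenium atom replaced by methylsulfanyl on an aromatic carbon between two ring nitrogen atoms gives an at least 1.1-fold lower number from compound 2 to compound 3 (0.05 log units; that floor lies within the scatter), and this figure is only a floor, so the true size of the step stays unknown. The value of compound 2 is a limit and not a number: the limit of > 100000 nM in this assay, at which 1 of the 3 values shown sits.

Hydrogen in place of methoxy on an aromatic carbon gives a 1.1-fold lower number from compound 1 to compound 3 (0.03 log units; within the scatter), so the methylsulfanyl compounds cannot be told apart in this comparison, and both remain weak.

The compounds shown carry only selenium or methylsulfanyl on this carbon, which leaves open what an amine or a longer sulfur-linked chain would do there. They also leave open whether any group at this position can bring the read-out far below the level of compound 3.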